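The compounds below may be only part of what the source reports. "The series", "measured", "known", "first", "only" and "open" are said of these compounds alone.

Compound 1 `Cc1ccc(S(=O)(=O)CCO)cc1C#Cc1cc(Cl)ccc1OCC(=O)O` gives 19 nM in an assay on CHO cells for displacement of a labelled ligand from prostaglandin D2 receptor 2 (Homo sapiens), read by scintillation counting; a lower number here means a stronger inhibitor, a higher number a weaker inhibitor.
Compound 2 `Cc1ccc(S(=O)(=O)N(C)CCCN(C)C)cc1C#Cc1cc(Cl)ccc1OCC(=O)O` gives 287 nM in this assay.
Compound 3 `CCS(=O)(=O)c1ccc(C)c(C#Cc2cc(Cl)ccc2OCC(=O)O)c1` gives 8.6 nM in this assay.

Compound 3 has the lowest number of the three, and both of its steps to the others lie beyond the scatter: the step of a 2.2-fold lower number from compound 1 to compound 3 (0.34 log units; beyond the scatter) is modest, while the step of a 33-fold lower number from compound 2 to compound 3 (1.52 log units; beyond the scatter) is large. Compound 4 `Cc1ccc(S(=O)(=O)N2CCOCC2)cc1C#Cc1cc(Cl)ccc1OCC(=O)O` differs from compound 3 in one place: morpholin-4-yl in place of ethyl on a sulfonyl sulfur. Both measured steps bear on this change, since each also alters the group on the sulfonyl sulfur. A nitrogen-bearing group there, in compound 2, went with a far higher number; a hydroxy-bearing chain, in compound 1, with only a modestly higher one. Morpholin-4-yl brings a ring with both a nitrogen and an oxygen and no net charge, so a higher number is expected for compound 4, but well short of the change seen for compound 2; the expected step is a 4.7-fold higher number from compound 3 to compound 4 (0.67 log units; beyond the scatter). Compound 4 is therefore estimated at 40 nM, within 12 nM to 150 nM.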

Compound 4, inhibition constant: 3.6 nM
For compound 4 the middle estimate is 11-fold (1.05 log units) above the measured one, outside the stated range (below it).
By their numbers in this assay, from the lowest: compound 4; then compound 3; then compound 1; then compound 2.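

Morpholin-4-yl on the sulfonyl sulfur gives a 2.4-fold lower number from compound 3 to compound 4 (0.38 log units; beyond the scatter) in this assay, so a nitrogen attached to that sulfur does not by itself go with a higher number. The same group gives an 80-fold lower number from compound 2 to compound 4 (1.90 log units; beyond the scatter) when it replaces (3-(dimethylamino)propyl)(methyl)amino, which also puts a nitrogen on the sulfur, and a 5.3-fold lower number from compound 1 to compound 4 (0.72 log units; beyond the scatter) when it replaces 2-hydroxyethyl. Open, going by these compounds, is whether the ring oxygen matters: a piperidin-1-yl group, with carbon there, or a piperazin-1-yl group, with nitrogen there, would test it. Nothing given here explains these steps.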